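The source may report more compounds than this note shows. Statements on the series, on what has been measured and on what is new or still open speak of the compounds shown alone.

Compound 1 (`CCc1nc(-c2ccc(C(C)(C)C)cc2)c(C(=O)N2CCN(c3cccc(OC)c3)CC2)o1`) offers no number to work from: in a functional assay on HL-60 cells (Homo sapiens) for inhibition, read by MTT assay, with a stated time of 72 h (on this read-out higher numbers stand for weaker inhibition and lower numbers for stronger inhibition), compound 1 is reported as "not active" (no number reported). Two related compounds give some context, although each differs from compound 1 in more than one place. Compound 2 (`Cc1ccc(C)c(N2CCN(C(=O)c3oc(C)nc3-c3ccccc3Cl)CC2)c1`) gives > 1000 nM, which is a limit of the assay and not a measured number. Compound 3 (`Cc1ccc(N2CCN(C(=O)c3oc(C)nc3-c3ccccc3)CC2)c(C)c1`) gives 101 nM, a true number on the same read-out.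

Compound 4 (`CCc1nc(-c2ccc(C(C)C)cc2)c(C(=O)N2CCN(c3cccc(OC)c3)CC2)o1`) has not yet been measured in this assay. The structural change is hydrogen in place of methyl on a saturated chain carbon bound to an aromatic carbon and two saturated chain carbons, so that tert-butyl becomes isopropyl and 4-(tert-butyl)phenyl becomes 4-isopropylphenyl. The rest of the molecule stays the same.

Going by the values given here, no measured pair shows what this change does, so the expectation is tentative. A small step is expected in this assay, and any shift would be toward lower numbers, given that compound 1 stands at "not active" (no number reported). Compound 4 is therefore expected to remain a weak inhibitor, and a report without a number is quite likely. For compound 4 the estimated value is 2000 nM, with an expected range from 300 nM to 10000 nM.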

Compound 4, half-maximal inhibitory concentration: 887 nM
For compound 4 the middle estimate is 2.3-fold (0.35 log units) above the measured one; low and high end bracket the measured number.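

No step can be read between compound 1 and compound 4: in this assay compound 1 stands as "not active" (no number reported), so the value of compound 4, 887 nM, has no number to be set against. The compounds shown leave open how far going from 4-(tert-butyl)phenyl to 4-isopropylphenyl alone moves the value in this assay.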